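Aminophenyl alkyne series: removing the amino group

The compounds below may be only part of what the source reports. "The series", "measured", "known", "first", "only" and "open" are said of these compounds alone.

Measured compounds:
Compound 1 `COC(=O)c1sc2cc(C#Cc3ccccc3OC)cnc2c1N`: in a functional assay on MCF7 cells (Homo sapiens) for inhibition, read by sulforhodamine B assay, with a stated time of 48 h (on this read-out lower numbers stand for stronger inhibition of growth and higher numbers for weaker inhibition of growth), compound 1 gives > 47300 nM, a limit of the assay rather than a number.
Compound 2 `COC(=O)c1sc2cc(C#Cc3ccccc3N)cnc2c1N`: compound 2 gives 4100 nM.
Compound 3 `COC(=O)c1sc2cc(C#Cc3cccc(OC)c3)cnc2c1N`: compound 3 gives 33400 nM.

Compound 2 holds the lowest of the two numbers shown; compound 3 is its nearest neighbour, and the step of an 8.1-fold higher number from compound 2 to compound 3 (0.91 log units; beyond the scatter) is beyond the scatter. Compound 1 contributes only a limit (the limit of > 47300 nM in this assay, at which 1 of the 3 values shown sits).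

The unmeasured compound 4 `COC(=O)c1sc2cc(C#Cc3ccccc3)cnc2c1N` differs from compound 2 in one place: hydrogen in place of amino on an aromatic carbon.

Within the data shown here, two measured steps bear on this change. The step of an at least 11-fold lower number from compound 1 to compound 2 (1.06 log units; beyond the scatter) shows that installing the amino group in place of methoxy is accompanied by a large fall in the number. The step of an 8.1-fold higher number from compound 2 to compound 3 (0.91 log units; beyond the scatter) shows that exchanging the 2-aminophenyl group for 3-methoxyphenyl is accompanied by a modest rise. Both point the same way: the amino group on the phenyl ring goes with the lower numbers in this series, and its replacement by hydrogen is expected to move compound 4 upward, beyond the scatter, toward the region occupied by compound 3 and compound 1.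

Compound 4 is therefore expected to give 25000 nM in this assay, within 8000 nM to 60000 nM, an expected step of a 6.1-fold higher number from compound 2 to compound 4 (0.79 log units; beyond the scatter).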

Compound 4, concentration for 50% growth inhibition: > 150000 nM
Compound 4 ended at the assay's limit; the forecaster's own chance of this, stated with the estimate: 30%; middle value at least 6.0-fold (0.77 log units) from the limit.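

In this assay, among these compounds, the earlier compounds compared amino only with methoxy, whereas hydrogen on this aromatic carbon now gives the comparison against the unsubstituted phenyl: an at least 36-fold higher number from compound 2 to compound 4 (1.56 log units; beyond the scatter), so the 2-aminophenyl group stands well apart from phenyl. The 3-methoxyphenyl group also stands apart from phenyl, with an at least 4.4-fold higher number from compound 3 to compound 4 (0.65 log units; beyond the scatter), so within these compounds a lower number than that of the unsubstituted phenyl is not confined to the amino compound. Compound 4 sits at a limit of the assay and not at a number, so both steps give only a floor on their size: the limit of > 150000 nM in this assay, at which 1 of the 4 values shown sits.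

As far as these compounds go, the step between compound 1 and compound 4 cannot be read, and whether the 2-methoxyphenyl group differs from phenyl stays open, as compound 1 also stands at a limit: the limit of > 47300 nM in this assay, at which 1 of the 4 values shown sits. Also open, from the compounds shown here alone, is whether a hydroxyl, a methylamino or an acetamido group on the same aromatic carbon would keep the number of compound 2.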